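Working notes: from compound 3 to compound 4

The source may hold more compounds than are shown below. What is called first, only, known or untested is meant among the compounds shown, and "the series" means these compounds.

Measured in a functional assay on MDA-MB-231 cells (Homo sapiens) for antiproliferative activity, with a stated time of 4 days; a higher number here means a weaker inhibitor, a lower number a stronger inhibitor:
- compound 1 `COc1ccc(-c2[nH]c3ccc(C(C)C)cc3c2C=O)cc1`: 29 nM
- compound 2 `Cc1ccc(-c2[nH]c3ccc(C)cc3c2C=O)cc1`: 48 nM
- compound 3 `CCCCc1ccc2[nH]c(-c3ccc(C)cc3)c(C=O)c2c1`: 34 nM

In this assay, compound 3 gives 34 nM, which lies within the scatter of the values of both compound 1 and compound 2. The three measured compounds therefore offer no firm ranking around compound 3.

The next compound is compound 4 `CCCCc1ccc2[nH]c(-c3ccc(F)cc3)c(C=O)c2c1`. The change is fluoro in place of methyl on an aromatic carbon, or 4-methylphenyl to 4-fluorophenyl.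

Going by the values given here, only one measured step is available, a 1.4-fold lower number from compound 2 to compound 3 (0.15 log units; within the scatter). It is small, but it concerns propyl in place of hydrogen on a saturated chain carbon, so it sits at a different place from the present change. Among the compounds with values here, no measured step covers methyl and fluoro at this place, and no measured compound carries fluoro. The data therefore give no direction for the change, and no shift beyond the scatter is expected in this assay. The expected result is a 1.3-fold higher number from compound 3 to compound 4 (0.12 log units; within the scatter), a step that remains an estimate with no measured support at this place. For compound 4 the estimated value is 45 nM, with an expected range of 16 nM to 130 nM.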

Compound 4, half-maximal inhibitory concentration: 350 nM
For compound 4 the middle estimate is 7.8-fold (0.89 log units) below the measured one; the measured number lies above the stated range.
By their numbers in this assay, from the lowest: compounds 1, 3 and 2 (each within the scatter of the next); then compound 4.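

In this assay, going by these compounds alone, the change from 4-methylphenyl to 4-fluorophenyl gives a 10-fold higher number from compound 3 to compound 4 (1.01 log units; beyond the scatter) and is the first step to lie beyond the scatter. Within the data shown here, the only earlier step, a 1.4-fold lower number from compound 2 to compound 3 (0.15 log units; within the scatter) on the saturated chain, stayed within the scatter, so this place on the aromatic ring is the first at which the series shows a clear response. The exchange is one heavy atom for one heavy atom, with no ring, hydrogen-bond donor, hydrogen-bond acceptor or net charge on either side, and no measurement shown here accounts for the size of the step.

Going by these compounds, whether the loss follows from the presence of fluoro or from the absence of methyl stays open, and chloro or an amine at the same place, set against compound 3, would help to separate the two readings. Also open, on these data alone, is whether the step carries over to a shorter chain on the core, which a fluoro counterpart of compound 2 would test in this assay.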